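Cyclopropyl for tert-Butyl on a Sulfonamide Nitrogen

The source may hold more compounds than are shown below. What is called first, only, known or untested is meant among the compounds shown, and "the series" means these compounds.

Three compounds have been run in an ADME assay on microsomes from liver (Mus musculus) for metabolic stability, read by LC-MS, with a stated time of 40 min, tested at 0.5 uM (on this read-out higher numbers stand for fast clearance and lower numbers for slow clearance), and all three return a limit rather than a number. Compound 1 `O=C(Nc1cccc(S(=O)(=O)C2CCCC2)n1)c1ccc(NCCO)cc1N1CCC2(CC1)CC2` gives > 399 mL.min-1.g-1 in this assay, which is a limit. Compound 3 `O=C(Nc1cccc(S(=O)(=O)N2CCCCC2)c1)c1cn[nH]c1-c1ccc(Cl)cc1` gives > 399 mL.min-1.g-1, again a limit. Compound 2 `CC(C)(C)NS(=O)(=O)c1cccc(NC(=O)c2cccnc2N2CCC3(CC2)CC3)c1` gives > 399 mL.min-1.g-1, also a limit, so compound 2 stands where the other two stand, as the evidence summarises: the limit of > 399 mL.min-1.g-1 in this assay, at which 3 of the 3 values shown sit. For the measured compounds named here, no step between measured compounds is available, since no two of them differ in a single place.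

The next compound, compound 4 `O=C(Nc1cccc(S(=O)(=O)NC2CC2)c1)c1cccnc1N1CCC2(CC1)CC2`, differs from compound 2 in one place: cyclopropyl in place of tert-butyl on a sulfonamide nitrogen. Going by the values given here, with every measured value sitting at the limit, there is no measured step on which to size this change, and the only guide is the reading of compound 2 itself. The step of an at least 1.1-fold lower number from compound 2 to compound 4 (0.05 log units; that floor lies within the scatter) is expected to stay within the scatter of this assay. The estimate for compound 4 is 350 mL.min-1.g-1, with a range from 150 mL.min-1.g-1 to 800 mL.min-1.g-1, and a good chance that this assay again reports only a limit.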

Compound 4, intrinsic clearance in microsomes: > 399 mL.min-1.g-1
Compound 4: no number, only a limit (the forecaster's own chance of this, stated with the estimate: 65%); at least 1.1-fold (0.05 log units) between middle value and limit.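

In this assay compound 4 gives > 399 mL.min-1.g-1, which is a limit. For the compounds shown here, compound 2 also stands at a limit, so no step from compound 2 to compound 4 can be read. From the compounds shown here alone, whether cyclopropyl in place of tert-butyl on this sulfonamide nitrogen changes clearance at all remains open.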